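Trading a decyl chain for a phenylpropyl group

A few compounds are considered here, and "the series" means these few. Any claim that something is new, unique, unknown or untested is made for them only; others in the source may bear on it.

Compound 1 `CCCCOC(=O)C(=O)C(CC)NC(=O)C(CC(C)C)NC(=O)OCc1ccccc1` gives 400 nM in an assay on isolated protein (Oryctolagus cuniculus) for inhibition of Calpain-2 catalytic subunit (Homo sapiens), at pH 8.0 (a lower number here means a stronger inhibitor, a higher number a weaker inhibitor), and compound 2 `CCCCCCCCCCNC(=O)C(=O)C(CC)NC(=O)C(CC(C)C)NC(=O)OCc1ccccc1` gives 600 nM in this assay; the two numbers sit within the scatter of each other, as a 1.5-fold higher number from compound 1 to compound 2 (0.18 log units; within the scatter) shows, so neither can be called stronger. Compound 3 `CCC(NC(=O)C(CC(C)C)NC(=O)OCc1ccccc1)C(=O)C(=O)NCCCc1ccccc1` differs from compound 2 by phenyl in place of heptyl on a saturated chain carbon, three bonds along the chain from an amide-type nitrogen. For the measured compounds named here, the only measured step, swapping butoxy for decylamino, stayed within the scatter, and no measured step involves a phenyl ring. Compound 3 is therefore expected to show a 1.2-fold lower number from compound 2 to compound 3 (0.08 log units; within the scatter), with an estimated value of 500 nM, between 200 nM and 1500 nM.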

Compound 3, inhibition constant: 43 nM
Compound 3: the middle estimate sits 12-fold (1.07 log units) above what was measured; the whole stated range lies above it.
By their numbers in this assay, from the lowest: compound 3; then compounds 1 and 2 (each within the scatter of the next).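

Phenyl in place of heptyl on this chain gives a 14-fold lower number from compound 2 to compound 3 (1.14 log units; beyond the scatter) and shows that the end of the chain matters here, which the earlier step could not show: decylamino in place of butoxy gave only a 1.5-fold higher number from compound 1 to compound 2 (0.18 log units; within the scatter) and no clear change. (3-Phenylpropyl)amino in place of butoxy gives a 9.3-fold lower number from compound 1 to compound 3 (0.97 log units; beyond the scatter) and so the gain appears with the phenyl ring present, not with decylamino. Going by these compounds, whether a benzyl or phenethyl group, or a pyridine ring in place of phenyl, would keep this gain stays open. Nothing measured here says why the ring brings this gain.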